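Working notes: acetamido in place of the carbamoyl arm

A few compounds are considered here, and "the series" means these few. Any claim that something is new, unique, unknown or untested is made for them only; others in the source may bear on it.

Among the compounds with values here, compound 2 `Cc1cc(C(=O)NCc2ccncc2)nn1Cc1cc(Cl)ccc1OCc1ccccc1` holds the lowest of the two numbers measured so far in an assay on CHO-K1 cells for displacement of a labelled ligand from prostaglandin E2 receptor EP1 subtype (Homo sapiens) (on this read-out higher numbers stand for weaker inhibition and lower numbers for stronger inhibition), giving 79.4 nM. Within the data shown here, its only neighbour is compound 1 `Cc1cc(C(=O)Nc2ccccn2)nn1Cc1cc(Cl)ccc1OCc1ccccc1`, which in this assay gives 126 nM; the step of a 1.6-fold lower number from compound 1 to compound 2 (0.20 log units; within the scatter) stays inside the usual scatter, so no order between the two is claimed.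

Compound 3 `CC(=O)Nc1cc(C)n(Cc2cc(Cl)ccc2OCc2ccccc2)n1` carries acetamido in place of ((pyridin-4-yl)methyl)carbamoyl on an aromatic carbon. Among the measured compounds shown here, the single measured step, a 1.6-fold lower number from compound 1 to compound 2 (0.20 log units; within the scatter), concerns the same side of the core but only swapped one pyridine-bearing substituent on the amide nitrogen for another while the carbamoyl itself remained; it does not test removal of the whole ((pyridin-4-yl)methyl)carbamoyl and its six-membered aromatic ring. For the measured compounds named here, no measured step therefore bears directly on the change to compound 3, and the series gives no anchor for a reversed, much shorter acetamido at this carbon.

Given that the change is far larger than the one step on record, a step beyond the scatter toward a higher number is expected, as a 6.3-fold higher number from compound 2 to compound 3 (0.80 log units; beyond the scatter), though the direction rests on nothing measured. Compound 3 is accordingly estimated at 500 nM, with a plausible range from 100 nM to 3000 nM.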

Compound 3, half-maximal inhibitory concentration: 316 nM
For compound 3 the middle estimate is 1.6-fold (0.20 log units) above the measured one; the measured number falls inside the stated range.
By their numbers in this assay, from the lowest: compounds 2 and 1 (each within the scatter of the next); then compound 3.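

Putting acetamido on this aromatic carbon, next to the ring nitrogen, gives in this assay a 4.0-fold higher number from compound 2 to compound 3 (0.60 log units; beyond the scatter), and set against the other amide it gives a 2.5-fold higher number from compound 1 to compound 3 (0.40 log units; beyond the scatter). Within the data shown here, this is the first change to move the number beyond the scatter, and it does so in the same direction from both amides, so the carbamoyl arms with their pyridine rings go with lower numbers than the ringless acetamido does; yet both steps are modest, and the pyridine ring is not needed for compound 3 to give a measurable number. Nothing on record accounts for this rise.

The step changes several things at once, since the amide is reversed, the arm is shortened and the six-membered aromatic ring is lost, and the compounds shown do not separate these contributions. A carboxylic acid, a plain primary carboxamide or a phenylacetamido group at this carbon would show whether the ring, the length of the chain or the direction of the amide carries the difference.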